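This account rests on a few compounds, and the source may have more. Where it says the series, first, only, none or still open, it means among the compounds named here.

Series notes. For the measured compounds named here, compound 1 `COC(=O)c1ccc(N2CCC(O)(Cn3cnc4c(Br)n(C)nc4c3=O)CC2)c(Cl)c1` gives 157 nM in an assay on Sf21 cells for inhibition of ubiquitin carboxyl-terminal hydrolase 7 (Homo sapiens), read by spectrophotometry, with stated times of 30 min and 2 h (a higher number here means a weaker inhibitor, a lower number a stronger inhibitor), the only number in the set. Compound 2 `COC(=O)C(c1ccccc1Cl)N1CCC(O)(Cn2cnc3c(cnn3-c3ccc(F)cc3)c2=O)CC1` carries a different core and a (2-chlorophenyl)(methoxycarbonyl)methyl group on the amine nitrogen in a ring; in this assay compound 2 stands at "not determined" (no result reported), so there is no number to place it against compound 1. Compound 3 `O=c1c2cnn(-c3ccc(F)cc3)c2ncn1CC1(O)CCN(Cc2ccccc2Br)CC1` keeps the core of compound 2 and changes only the group on that nitrogen: 2-bromobenzyl in place of (2-chlorophenyl)(methoxycarbonyl)methyl on an amine nitrogen in a ring. Going by the values given here, with no measured pair of this kind, no step can be computed; the change is expected to move the value in this assay by an amount that may not exceed the scatter, with no direction preferred. Resting on compound 1 as the only anchor, compound 3 is estimated at 300 nM in this assay, with a range from 40 nM to 3000 nM reflecting the different core and the untested change.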

Compound 3, half-maximal inhibitory concentration: 3100 nM
For compound 3 the middle estimate is 10-fold (1.01 log units) below the measured one; measured number above the stated range.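

No step can be read between compound 2 and compound 3 in this assay, as compound 2 has no number to set against compound 3. The compounds shown leave open how 2-bromobenzyl compares with (2-chlorophenyl)(methoxycarbonyl)methyl on the ring nitrogen. No evidence bears on this result.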